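This account rests on a few compounds, and the source may have more. Where it says the series, first, only, none or still open, it means among the compounds named here.

In a functional assay on SK-OV-3 cells (Homo sapiens) for cytotoxicity, read by spectrophotometry, with a stated time of 72 h (on this read-out higher numbers stand for weaker inhibition and lower numbers for stronger inhibition), compound 1 `COc1cc(-n2c(-c3ccc([N+](=O)[O-])cc3)cccc2=O)cc(OC)c1OC` gives 201 nM and compound 2 `COc1cc(-n2c(-c3cccc(F)c3)cccc2=O)cc(OC)c1OC` gives 472 nM, so compound 2 holds the higher of the two numbers, meaning the weaker inhibition. Compound 3 `COc1ccc(-c2cccc(=O)n2-c2cc(OC)c(OC)c(OC)c2)cc1C` keeps the shared core but carries 4-methoxy-3-methylphenyl in place of 3-fluorophenyl on an aromatic carbon, next to the ring nitrogen: 4-methoxy-3-methylphenyl in place of 3-fluorophenyl on an aromatic carbon. For the measured compounds named here, only one measured step bears on this change, as it also swaps one substituted phenyl group for another: a 2.3-fold higher number from compound 1 to compound 2 (0.37 log units; beyond the scatter). That step is modest, though beyond the scatter, and a single step cannot show what the incoming group will do. A step of similar modest size is therefore expected, leaning toward stronger inhibition in this assay. The expected change is a 2.4-fold lower number from compound 2 to compound 3 (0.37 log units; beyond the scatter). For compound 3 the estimated value is 200 nM, with an expected range of 50 nM to 700 nM.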

Compound 3, half-maximal inhibitory concentration: 583 nM
Beside the measured number, compound 3's estimate is 2.9-fold (0.46 log units) below it, within the range that was stated.
By their numbers in this assay, from the lowest: compound 1; then compounds 2 and 3 (each within the scatter of the next).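

In this assay, a third substituted phenyl group at this position, on an aromatic carbon next to the ring nitrogen, gives a 1.2-fold higher number from compound 2 to compound 3 (0.09 log units; within the scatter) and so cannot be told apart from 3-fluorophenyl here. Set against 4-nitrophenyl, the same group gives a 2.9-fold higher number from compound 1 to compound 3 (0.46 log units; beyond the scatter) and this modest step, like the one already seen for 3-fluorophenyl, leaves compound 1 with the lowest number of the three. No measurement here gives a reason for this pattern.

From the compounds shown here alone, all three compounds carry a substituted phenyl group at this position, so what an amine or a carboxylic acid would do there remains open. Also open, going by these compounds, is whether the methoxy or the methyl of 4-methoxy-3-methylphenyl matters on its own.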